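The source may hold more compounds than are shown below. What is called first, only, known or untested is meant among the compounds shown, and "the series" means these compounds.

Measured so far:
compound 1 `CS(=O)(=O)CCCn1c(Cn2c(=O)n(C3CN(S(C)(=O)=O)C3)c3ccncc32)cc2cc(Cl)ccc21` — > 50000 nM
compound 2 `O=c1n(Cc2cc3cc(Cl)ccc3n2CCCCO)c2cnccc2n1C1CC1` — > 50000 nM
compound 3 `CS(=O)(=O)c1ccc(-n2c(=O)n(Cc3cc4cc(Cl)ccc4n3CCCC#N)c3cnccc32)cc1` — > 50000 nM

In an ADME assay on HeLa cells (Homo sapiens) for cytotoxicity, read by ATP content, with a stated time of 3 days (a higher number here means that more compound is tolerated, a lower number that less compound is tolerated), compound 1 gives > 50000 nM, which is a limit of the assay and not a number. Compound 2 gives > 50000 nM, again a limit. Compound 3 gives > 50000 nM, also a limit. Among the compounds with values here, all three values shown sit at the limit of > 50000 nM in this assay, at which 3 of the 3 values shown sit, so compound 3 stands at the ceiling of what was tested, and no step between measured compounds can be read. Compound 4 `N#CCCCn1c(Cn2c(=O)n(-c3ccncc3)c3ccncc32)cc2cc(Cl)ccc21` differs from compound 3 by pyridin-4-yl in place of 4-(methylsulfonyl)phenyl on an aromatic nitrogen. For this assay the expectation is no step beyond the scatter, with compound 4 most likely reported as a limit as well. The expected step from compound 3 to compound 4 is a number no higher from compound 3 to compound 4 (the limit leaves the size open). Compound 4 is estimated at 50000 nM, within 25000 nM to 100000 nM.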

Compound 4, half-maximal cytotoxic concentration: > 50000 nM
Compound 4: a limit, no number; the forecaster's own chance of this, stated with the estimate: 85%; the middle value lies on the limit itself.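

Compound 4 gives > 50000 nM in this assay, a limit and not a number, so no step from compound 3 to compound 4 can be read: the limit of > 50000 nM in this assay, at which 4 of the 4 values shown sit.

Where the half-maximal cytotoxic concentration of any of these compounds actually lies, and whether swapping 4-(methylsulfonyl)phenyl for pyridin-4-yl alters it, stays open.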